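The source may report more compounds than this note shows. Statements on the series, on what has been measured and on what is new or still open speak of the compounds shown alone.

Compound 2 `CC(C)(C)C(=O)N1CCC[C@H]1C(=O)N1CCC(NS(=O)(=O)c2cc(S(=O)(=O)c3ccccc3)ccc2C(F)(F)F)CC1` in an assay on isolated protein for binding affinity to secreted frizzled-related protein 1 (Homo sapiens), read by fluorescence (on this read-out lower numbers stand for stronger inhibition and higher numbers for weaker inhibition), gives 40 nM, level with compound 1 `CC(C)C(=O)N1CCC[C@H]1C(=O)N1CCC(NS(=O)(=O)c2cc(S(=O)(=O)c3ccccc3)ccc2C(F)(F)F)CC1`, which gives 40 nM; together these are the lowest two of the three numbers. Compound 3 `O=C([C@@H]1CCCN1C(=O)c1ccncc1)N1CCC(NS(=O)(=O)c2cc(S(=O)(=O)c3ccccc3)ccc2C(F)(F)F)CC1` gives 70 nM. The steps of no change at the digits printed from compound 1 to compound 2 (within the scatter) and a 1.8-fold higher number from compound 2 to compound 3 (0.24 log units; within the scatter) both keep the carbonyl on this ring nitrogen and vary only the group attached to it. Compound 4 `O=C([C@@H]1CCCN1Cc1ccccc1)N1CCC(NS(=O)(=O)c2cc(S(=O)(=O)c3ccccc3)ccc2C(F)(F)F)CC1` differs from compound 2 by benzyl in place of (tert-butyl)carbonyl on an amine nitrogen in a ring. Within the data shown here, this removes the carbonyl itself, which no measured step does, so the measured steps bear only partly on it; they show only that the group on this nitrogen can be varied without a step beyond the scatter. For compound 4 a modest weakening is expected, a 3.0-fold higher number from compound 2 to compound 4 (0.48 log units; beyond the scatter). Compound 4 is estimated at 120 nM, in the range 40 nM to 400 nM.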

Compound 4, half-maximal inhibitory concentration: 1400 nM
The estimate for compound 4 lay 12-fold (1.07 log units) below the measured number; the whole stated range lies below it.
By their numbers in this assay, from the lowest: compounds 1, 2 and 3 (each within the scatter of the next); then compound 4.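

In this assay, benzyl on this ring nitrogen separates sharply from the groups that keep the carbonyl: a 35-fold higher number from compound 2 to compound 4 (1.54 log units; beyond the scatter), a 35-fold higher number from compound 1 to compound 4 (1.54 log units; beyond the scatter) and a 20-fold higher number from compound 3 to compound 4 (1.30 log units; beyond the scatter). Compound 3 also carries a six-membered aromatic ring on its carbonyl and stays within the scatter of compound 1 and compound 2, so an aromatic ring alone does not go with the large step. No measurement on hand explains the step.

Open, from the compounds shown here alone, is whether benzoyl on this nitrogen would stay level with compound 1, and whether a plain methyl, without carbonyl or ring, gives a step of the same size.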